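Shortening a Chain and Moving a Fluorine

A few compounds are considered here, and "the series" means these few. Any claim that something is new, unique, unknown or untested is made for them only; others in the source may bear on it.

Compound 1 `CN1CCCN(CCNc2nccc(-c3c(-c4cccc(O)c4)nc4sccn34)n2)S1(=O)=O` and compound 2 `O=S(=O)(NCCCNc1nccc(-c2c(-c3cccc(O)c3)nc3sccn23)n1)c1cccc(F)c1` have both been tested in a toxicity assay on BJ cells (Homo sapiens) for inhibition, read by MTT assay, with a stated time of 48 h; a lower number here means a stronger inhibitor, a higher number a weaker inhibitor. Compound 1 gives 75600 nM, and compound 2 gives 45200 nM. With only these two numbers, compound 2 cannot be told apart from compound 1.

Compound 3 `O=S(=O)(NCCNc1nccc(-c2c(-c3cccc(O)c3)nc3sccn23)n1)c1ccc(F)cc1` comes next, and the change is ((4-fluorophenyl)sulfonyl)amino in place of (((3-fluorophenyl)sulfonyl)amino)methyl on a saturated chain carbon, two bonds along the chain from a nitrogen on an aromatic ring. In short, ((4-fluorophenyl)sulfonyl)amino stands in place of (((3-fluorophenyl)sulfonyl)amino)methyl on a saturated chain carbon, two bonds along the chain from a nitrogen on an aromatic ring.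

Going by the values given here, only one measured step bears on this. It exchanged a group with a non-aromatic ring for one with an aromatic ring, and it came to a 1.7-fold lower number from compound 1 to compound 2 (0.22 log units; within the scatter). No change beyond the scatter is therefore expected, and the expected step is a 1.1-fold higher number from compound 2 to compound 3 (0.04 log units; within the scatter). For compound 3 the estimated value is 50000 nM, with an expected range of 22000 nM to 100000 nM.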

Compound 3, half-maximal inhibitory concentration: 50600 nM
Compound 3: the middle estimate sits 1.0-fold (0.01 log units) below what was measured; measured number inside the range.
By their numbers in this assay, from the lowest: compounds 2, 3 and 1 (each within the scatter of the next).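

In this assay, replacing (((3-fluorophenyl)sulfonyl)amino)methyl with ((4-fluorophenyl)sulfonyl)amino gives a 1.1-fold higher number from compound 2 to compound 3 (0.05 log units; within the scatter) and replacing the group with the non-aromatic ring gives a 1.5-fold lower number from compound 1 to compound 3 (0.17 log units; within the scatter), so all three groups shown at this position now give numbers that cannot be told apart. The step from the 3-fluorophenyl group to the 4-fluorophenyl group alters the chain and the place of the fluorine together, and with no change beyond the scatter, neither alteration can be judged alone. No measurement at hand explains why the numbers stay so close.

From the compounds shown here alone, it remains open whether the chain and the fluorine would each matter if changed separately. Going by these compounds, it is also open whether a quite different group at this position, such as an amine or a carboxylic acid, would move the number beyond the scatter.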